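The source may report more compounds than this note shows. Statements on the series, on what has been measured and on what is new or still open speak of the compounds shown alone.

In a functional assay on HeLa cells (Homo sapiens) for antiproliferative activity, read by MTT assay, with a stated time of 72 h (a lower number here means a stronger inhibitor, a higher number a weaker inhibitor), compound 1 `COc1cc(-c2nccn2CC(C)C)cc(OC)c1OC` stands at > 100000 nM, which is a limit of the assay and not a number. Compound 3 `COc1cc(-c2nccn2-c2ccc(Br)cc2)cc(OC)c1OC` has not yet been measured. It differs from compound 1 by 4-bromophenyl in place of isobutyl on an aromatic nitrogen, with 4-bromophenyl in place of isobutyl on an aromatic nitrogen. Compound 2 `COc1cc(OC)cc(-n2ccnc2-c2cc(OC)c(OC)c(OC)c2)c1`, which also carries an aromatic ring on that nitrogen, gives a measured 41400 nM, so stronger inhibition is expected in this assay. The estimated size of this change is an at least 12-fold lower number from compound 1 to compound 3 (1.09 log units; beyond the scatter). For compound 3, the expected value is 8000 nM, with an estimated range of 500 nM to 60000 nM.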

Compound 3, half-maximal inhibitory concentration: 3300 nM
Compound 3: the middle estimate sits 2.4-fold (0.38 log units) above what was measured, and the stated range covers the measured number.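

In this assay, 4-bromophenyl in place of isobutyl on the aromatic nitrogen gives an at least 30-fold lower number from compound 1 to compound 3 (1.48 log units; beyond the scatter) and so brings a step at this position that can be read, with a large drop in the number. The value of compound 1 is a limit and not a number, so the step gives only a bound on the size of this change: the limit of > 100000 nM in this assay, at which 1 of the 3 values shown sits. The compounds shown leave open whether the ring or the bromine carries the change, which a plain phenyl or a benzyl group on that nitrogen would separate.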